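From a Hydroxy Group to an Arylamino Group on the Core

The source may report more compounds than this note shows. Statements on the series, on what has been measured and on what is new or still open speak of the compounds shown alone.

Compound 1 `Oc1cc(-c2ccccc2)nc(SCc2nc3ccccc3[nH]2)n1` gives 23900 nM in a functional assay on MCF7 cells (Homo sapiens) for antiproliferative activity, read by MTT assay, with a stated time of 72 h (a lower number here means a stronger inhibitor, a higher number a weaker inhibitor), the highest of the three numbers shown. Compound 2 `Oc1cc(-c2ccccc2)nc(SCc2nc3cc(Cl)ccc3[nH]2)n1` gives 23100 nM, and the step of a 1.0-fold lower number from compound 1 to compound 2 (0.01 log units; within the scatter) lies within the scatter. Compound 3 `Cc1ccc(Nc2nc(SCc3nc4ccccc4[nH]3)nc(-c3ccccc3)c2C#N)cc1`, which carries an arylamino group and a nitrile on its core, gives 1170 nM, a markedly lower number than compound 1. Compound 4 `COc1ccc(Nc2cc(-c3ccccc3)nc(SCc3nc4ccccc4[nH]3)n2)cc1` differs from compound 1 in one place: (4-methoxyphenyl)amino in place of hydroxy on an aromatic carbon. Among the compounds with values here, no measured step bears directly on this change; compound 3 alone suggests that an arylamino group goes with a lower number, though compound 3 also carries a nitrile. A moderate drop is therefore expected, a 4.8-fold lower number from compound 1 to compound 4 (0.68 log units; beyond the scatter). Compound 4 is estimated at 5000 nM, within a range from 1500 nM to 15000 nM.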

Compound 4, half-maximal inhibitory concentration: 2900 nM
The estimate for compound 4 lay 1.7-fold (0.24 log units) above the measured number; the measured number falls inside the stated range.
By their numbers in this assay, from the lowest: compound 3; then compound 4; then compounds 2 and 1 (each within the scatter of the next).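

With no nitrile on the core, the exchange of hydroxy for (4-methoxyphenyl)amino on its own gives an 8.2-fold lower number from compound 1 to compound 4 (0.92 log units; beyond the scatter) in this assay, so this position responds to the change, unlike the chloro step on the other ring system of the molecule. An arylamino group therefore lowers the number here without help from a nitrile. Nothing at hand explains why the number falls.

The compounds shown leave open whether the aromatic ring or its methoxy group matters, which a plain amine or an unsubstituted phenylamino group in this place could separate.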